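This account rests on a few compounds, and the source may have more. Where it says the series, first, only, none or still open, it means among the compounds named here.

Compound 1 `CCc1ccc(-c2nn3cc(-c4cccc(N)c4)nc3s2)cc1` gives 8200 nM in a functional assay on FM3A cells (Mus musculus) for inhibition, read by cell counting, with a stated time of 2 days; on this read-out higher numbers stand for weaker inhibition and lower numbers for stronger inhibition. Compound 2 `C=C(Br)C(=O)Nc1cccc(-c2cn3nc(-c4ccc(CC)cc4)sc3n2)c1` carries (1-bromoethenyl)carbonyl on the nitrogen and gives 3300 nM in this assay; the step is a 2.5-fold lower number from compound 1 to compound 2 (0.40 log units; beyond the scatter). Compound 3 `CCOc1ccc(-c2nn3cc(-c4cccc(N)c4)nc3s2)cc1`, with ethoxy in place of ethyl, gives only a limit in this assay, >= 250000 nM. The corresponding step is an at least 30-fold higher number from compound 1 to compound 3 (1.48 log units; beyond the scatter), noted as the limit of >= 250000 nM in this assay, at which 1 of the 3 values shown sits.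

Compound 2 thus has the lowest of the two numbers in this assay, with compound 1 nearest at a modestly higher number; the third value is a limit.

Compound 4 `C=C(Br)C(=O)Nc1cccc(-c2cn3nc(Cc4cccc(OC)c4)sc3n2)c1` differs from compound 2 by 3-methoxybenzyl in place of 4-ethylphenyl on an aromatic carbon. Going by the values given here, no measured step changes this ring in the same way. The nearest evidence is the step from compound 1 to compound 3, where an oxygen-bearing substituent on the same ring gave a large weakening. A weakening beyond the scatter is therefore expected for compound 4 in this assay, estimated as a 9.1-fold higher number from compound 2 to compound 4 (0.96 log units; beyond the scatter), though smaller than that step since the ethyl-bearing ring is replaced outright rather than oxygenated. The estimate for compound 4 in this assay is 30000 nM, between 5000 nM and 200000 nM.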

Compound 4, half-maximal inhibitory concentration: 1100 nM
The estimate for compound 4 lay 27-fold (1.44 log units) above the measured number, outside the stated range (below it).
By their numbers in this assay, from the lowest: compound 4; then compound 2; then compound 1. At a limit, above all of these: compound 3.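

In this assay, 3-methoxybenzyl in place of 4-ethylphenyl gives a 3.0-fold lower number from compound 2 to compound 4 (0.48 log units; beyond the scatter), so this position accepts a benzyl group as well as a directly attached phenyl group. An oxygen-bearing substituent on this aromatic ring therefore does not weaken inhibition in every case, as the methoxy group of compound 4 shows. Compound 3, with ethoxy on its ring and a free amine in place of the (1-bromoethenyl)carbonyl amide, goes against this and gives only a limit: the limit of >= 250000 nM in this assay, at which 1 of the 4 values shown sits.

As far as these compounds go, the step changes the benzyl attachment, the methoxy group and its ring position at once, so the share of each stays open; plain benzyl and 4-ethylbenzyl would separate them. From the compounds shown here alone, how an amine or a carboxylic acid on this ring would read also stays open.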